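Amide group swap from compound 3 to compound 4

The source may hold more compounds than are shown below. What is called first, only, known or untested is meant among the compounds shown, and "the series" means these compounds.

Values in an ADME assay on microsomes from liver (Homo sapiens) for metabolic stability, read by LC-MS, using NADPH, with a stated time of 30 min, tested at 0.1 uM; a lower number here means that less of the compound is left, a higher number that more of the compound is left:
- compound 1 `C[C@@]1(c2cc(NC(=O)c3cnc(OCF)cn3)ccc2F)C=C(CF)OC(N)=N1`: 86%
- compound 2 `C[C@@]1(c2cc(NC(=O)c3ncc(C#N)cc3Cl)ccc2F)C=C(CF)OC(N)=N1`: 57%
- compound 3 `Cc1cc(C#N)cnc1C(=O)Nc1ccc(F)c([C@]2(C)C=C(CF)OC(N)=N2)c1`: 63%

Compound 3 belongs to the lower pair of the three numbers. Within that pair the measured step is a number 6 percentage points higher from compound 2 to compound 3 (within the scatter). The gap to the highest number is a number 23 percentage points lower from compound 1 to compound 3 (beyond the scatter).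

Compound 4 `C[C@@]1(c2cc(NC(=O)c3coc(C(F)F)n3)ccc2F)C=C(CF)OC(N)=N1` has not yet been measured. Its difference is 2-(difluoromethyl)-1,3-oxazol-4-yl in place of 5-cyano-3-methylpyridin-2-yl on a carbonyl carbon. The 2-(difluoromethyl)-1,3-oxazol-4-yl group takes the place of 5-cyano-3-methylpyridin-2-yl on a carbonyl carbon.

Two measured steps change the group at this same place: a number 29 percentage points lower from compound 1 to compound 2 (beyond the scatter), and a number 23 percentage points lower from compound 1 to compound 3 (beyond the scatter). Both are modest. Among the compounds with values here, no measured compound carries the entering group, so these steps give only a rough size. Among the measured compounds, only compound 1 has fluorine in this group, and three compounds establish no pattern. The expectation leans on compound 1 at 86% and allows a modest upward step in this assay, smaller than the two measured ones. The expected step is a number 11 percentage points higher from compound 3 to compound 4 (beyond the scatter). For compound 4 the estimated value is 74%, with an expected range from 55% to 90%.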

Compound 4, percent of the compound remaining: 84%
The estimate for compound 4 lay 10 percentage points below the measured number, and the stated range covers the measured number.
By their numbers in this assay, from the lowest: compounds 2 and 3 (each within the scatter of the next); then compounds 4 and 1 (each within the scatter of the next).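

The change from the six-membered cyano pyridine to 2-(difluoromethyl)-1,3-oxazol-4-yl on the carbonyl carbon raises the number in this assay, with a number 21 percentage points higher from compound 3 to compound 4 (beyond the scatter) and a number 27 percentage points higher from compound 2 to compound 4 (beyond the scatter), while a number 2 percentage points lower from compound 1 to compound 4 (within the scatter) places it level with the 5-(fluoromethoxy)pyrazin-2-yl group. A high number at this place is therefore not confined to 5-(fluoromethoxy)pyrazin-2-yl and is also reached with a five-membered aromatic ring; among these four compounds, the two fluorine-bearing groups, in compound 1 and compound 4, give the upper pair, and no compound shown goes against this. No measurement is available that explains why these groups differ.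

The four compounds leave fluorine, ring type and the nitrile changing together, so the contribution of each remains unresolved. On these data alone, a 1,3-oxazol-4-yl carrying a nitrile, or a pyridin-2-yl carrying difluoromethyl in place of the nitrile, would help separate these features, and whether a group such as trifluoromethyl or an amine on the oxazole would keep the number at this level also remains open.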